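Replacing Trifluoromethyl With 1-Fluoroethyl in Compound 1

This account rests on a few compounds, and the source may have more. Where it says the series, first, only, none or still open, it means among the compounds named here.

Measured so far:
compound 1 `CNc1cc(Oc2ccc(NC(=O)Nc3cccc(C(F)(F)F)c3)cc2)ncn1` — 40 nM
compound 2 `Cc1cc(Oc2ccc(NC(=O)Nc3cccc(C(F)(F)F)c3)cc2)ncn1` — 160 nM

For the measured compounds named here, in an assay on isolated protein for inhibition of serine/threonine-protein kinase TNNI3K (Homo sapiens) (on this read-out lower numbers stand for stronger inhibition and higher numbers for weaker inhibition), compound 1 holds the lower of the two numbers; the only measured step, a 4.0-fold higher number from compound 1 to compound 2 (0.60 log units; beyond the scatter), is a swap on the shared core. Compound 3 `CNc1cc(Oc2ccc(NC(=O)Nc3cccc(C(C)F)c3)cc2)ncn1` has not been measured. It differs from compound 1 by 1-fluoroethyl in place of trifluoromethyl on an aromatic carbon. Going by the values given here, that measured step sits elsewhere in the molecule, so no measured step bears directly on this change; the expectation rests on the change alone. A small weakening is expected, a 2.5-fold higher number from compound 1 to compound 3 (0.40 log units; beyond the scatter). Compound 3 is therefore estimated at 100 nM, with a range from 30 nM to 400 nM.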

Compound 3, half-maximal inhibitory concentration: 79 nM
Compound 3: the middle estimate sits 1.3-fold (0.10 log units) above what was measured; low and high end bracket the measured number.
By their numbers in this assay, from the lowest: compounds 1 and 3 (each within the scatter of the next); then compound 2.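

In this assay, 1-fluoroethyl in place of trifluoromethyl on this aromatic carbon gives a 2.0-fold higher number from compound 1 to compound 3 (0.30 log units; within the scatter) so the two groups cannot be told apart on this read-out. For the compounds shown here, this is the first look at this position, and it shows that the change from three fluorine atoms to one leaves the number within normal scatter. Nothing measured here gives a reason for this result.

Still open, going by these compounds, is whether this position accepts a group with no fluorine at all, such as ethyl, an amine or a carboxylic acid. Also open, on these data alone, is whether the same swap holds with the methyl of compound 2 in place of methylamino.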